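This account rests on a few compounds, and the source may have more. Where it says the series, first, only, none or still open, it means among the compounds named here.

Measured so far:
compound 1 `COc1ccc2c(c1)C/C(=C\c1cc(-c3cc(OC)c(OC)c(OC)c3)n[nH]1)C2=O` — 2100 nM
compound 2 `COc1cc(-c2cc(/C=C/C(=O)c3ccc(F)c(F)c3)[nH]n2)cc(OC)c1OC` — 2500 nM

Both numbers come from a functional assay on MCF7 cells (Homo sapiens) for inhibition, read by MTT assay, with a stated time of 48 h; on this read-out lower numbers stand for stronger inhibition and higher numbers for weaker inhibition. Compound 1 holds the lowest of the two numbers in this assay; its nearest neighbour is compound 2, whose number sits higher by a margin that lies within the scatter, so the two cannot be ranked against each other. Among the compounds with values here, no pair among the measured compounds differs in one place only, so no single-change step is at hand from which the effect of a small substitution could be read.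

The next compound, compound 3 `COc1cc2c(cc1OC)C(=O)/C(=C/c1cc(-c3cc(OC)c(OC)c(OC)c3)n[nH]1)C2`, is the one-place variant of compound 1 in which the change is methoxy in place of hydrogen on an aromatic carbon — methoxy in place of hydrogen on an aromatic carbon of the shared core. Within the data shown here, with no measured step of this sort available, the expectation for this assay rests on compound 1 at 2100 nM alone: a step of modest size at most, in no firm direction, most likely not beyond the scatter. Compound 3 is therefore expected to give 1800 nM, with a range of 600 nM to 5500 nM. The step estimated here is a 1.2-fold lower number from compound 1 to compound 3 (0.07 log units; within the scatter).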

Compound 3, half-maximal inhibitory concentration: 2000 nM
Compound 3: the middle estimate sits 1.1-fold (0.05 log units) below what was measured; measured number inside the range.
By their numbers in this assay, from the lowest: compounds 3, 1 and 2 (each within the scatter of the next).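

In this assay the change to methoxy in place of hydrogen on an aromatic carbon of the shared core gives a 1.1-fold lower number from compound 1 to compound 3 (0.02 log units; within the scatter) and that step stays within the scatter. Within the data shown here, this is the first single-change step, and it shows that a methoxy group at this place, ortho to a methoxy group already present and on a six-membered aromatic ring of carbon only, leaves no readable difference between compound 1 and compound 3 on this read-out. No measurement is at hand that bears on the reason for this outcome.

The compounds shown leave open whether this aromatic carbon is equally indifferent to other groups: an amine, a carboxylic acid or a longer alkoxy chain in the same place could give a step beyond the scatter or could stay within it. One step at one position also cannot tell whether methoxy on another aromatic carbon of the core would behave in the same way.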